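The source may hold more compounds than are shown below. What is called first, only, known or untested is meant among the compounds shown, and "the series" means these compounds.

Measured in a functional assay on KB cells (Homo sapiens) for antiproliferative activity, read by sulforhodamine B assay, with a stated time of 3 days; on this read-out lower numbers stand for an effect already at smaller amounts and higher numbers for an effect only at larger amounts of compound:
compound 1 `CCC1=C(O)c2c(oc(-c3ccccc3)cc2=O)C(CC)(CC)C1=O`: > 236 uM
compound 2 `CCC1=C(O)c2c(oc(-c3ccc(OC(F)(F)F)cc3)cc2=O)C(CC)(CC)C1=O`: 36.5 uM

Among the compounds with values here, compound 2 at 36.5 uM holds the only actual number so far in this assay. Compound 1 stands at > 236 uM, which is a limit of the assay and not a number.

Compound 3 `CCC1=C(O)c2c(oc(-c3ccc(Br)cc3)cc2=O)C(CC)(CC)C1=O` has bromo in place of trifluoromethoxy on an aromatic carbon, para to a large group: bromo in place of trifluoromethoxy on an aromatic carbon. Within the data shown here, one measured step bears on this place: an at least 6.4-fold lower number from compound 1 to compound 2 (0.81 log units; beyond the scatter), with trifluoromethoxy in place of hydrogen. Among the measured compounds shown here, that step shows a group here can shift the read-out, but no measured step exchanges one group for another at this place, and bromo is untested. Compound 3 is therefore expected to stay near compound 2 at 36.5 uM, with a wide margin on a single step. The expected result is a 1.1-fold higher number from compound 2 to compound 3 (0.04 log units; within the scatter), with no shift beyond the scatter in either direction. For compound 3 the estimate is 40 uM, with an expected range from 15 uM to 120 uM.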

Compound 3, concentration for half-maximal effect: > 48.1 uM
Compound 3 was reported as a limit (the forecaster's own chance of this, stated with the estimate: 15%); middle value at least 1.2-fold (0.08 log units) away from the limit.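

Within the data shown here, the exchange of trifluoromethoxy for bromo at this place, the first swap of one group for another here, gives an at least 1.3-fold higher number from compound 2 to compound 3 (0.11 log units; that floor lies within the scatter). Among these compounds, compound 3 gives > 48.1 uM in this assay, which is a limit of the assay and not a number, so trifluoromethoxy remains the only group at this place with an actual number. The step from compound 1 to compound 3 cannot be read, since both compounds carry limits.

As far as these compounds go, whether bromo truly differs from trifluoromethoxy stays open, since the floor of the step does not separate the two groups. From the compounds shown here alone, what a methoxy, an amine or a carboxylic acid would give at this place also stays open, as do changes elsewhere on the shared core.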